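From 6-methylpyridin-3-yl to 5-chloropyridin-2-yl on an amide-type nitrogen

The source may hold more compounds than are shown below. What is called first, only, known or untested is meant among the compounds shown, and "the series" means these compounds.

Three measured compounds share one core and differ in the group on an amide-type nitrogen: compound 1 `Cc1cc(NC(=O)[C@H]2CN(C)C[C@@H]2c2ccc(/C=C/C(=O)Nc3ccccc3N)cc2)ccc1F`, compound 2 `CN1C[C@H](C(=O)Nc2ccc(Cl)cc2F)[C@@H](c2ccc(/C=C/C(=O)Nc3ccccc3N)cc2)C1` and compound 3 `Cc1ccc(NC(=O)[C@H]2CN(C)C[C@@H]2c2ccc(/C=C/C(=O)Nc3ccccc3N)cc2)cn1`. In an in vitro ADME assay on microsomes from liver (Homo sapiens) for pharmacokinetics, read by LC-MS, with a stated time of 10 min, tested at 1 uM (on this read-out higher numbers stand for fast clearance and lower numbers for slow clearance), compound 1 gives 15 mL/min/kg, compound 2 gives 11 mL/min/kg and compound 3 gives 8 mL/min/kg. The number for compound 3 lies within the scatter of both others, so the three cannot be ranked on these data.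

The unmeasured compound 4 `CN1C[C@H](C(=O)Nc2ccc(Cl)cn2)[C@@H](c2ccc(/C=C/C(=O)Nc3ccccc3N)cc2)C1` carries 5-chloropyridin-2-yl in place of 6-methylpyridin-3-yl on an amide-type nitrogen. Going by the values given here, no measured compound carries the entering group, so the evidence is indirect. The bearing comes from the three exchanges at the same place, which gave a 1.4-fold lower number from compound 1 to compound 2 (0.13 log units; within the scatter), a 1.9-fold lower number from compound 1 to compound 3 (0.27 log units; within the scatter) and a 1.4-fold lower number from compound 2 to compound 3 (0.14 log units; within the scatter). All three stayed within the scatter, so no step beyond the scatter is expected in this assay for this exchange either. The expected step is a 1.4-fold higher number from compound 3 to compound 4 (0.14 log units; within the scatter), a small one with no firm direction. Compound 4 is estimated at 11 mL/min/kg, with an expected range from 6 mL/min/kg to 20 mL/min/kg.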

Compound 4, clearance: 13 mL/min/kg
The estimate for compound 4 lay 1.2-fold (0.07 log units) below the measured number; low and high end bracket the measured number.
By their numbers in this assay, from the lowest: compounds 3, 2, 4 and 1 (each within the scatter of the next).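

In this assay, the exchange of one pyridinyl group for another at this amide-type nitrogen, with chlorine entering and the heavy-atom count unchanged, gave a 1.6-fold higher number from compound 3 to compound 4 (0.21 log units; within the scatter) and so stayed inside the usual variation, and compound 4 also sits close to both phenyl-bearing compounds, with a 1.2-fold higher number from compound 2 to compound 4 (0.07 log units; within the scatter) and a 1.2-fold lower number from compound 1 to compound 4 (0.06 log units; within the scatter) as the remaining steps. With this fourth group, all six exchanges among the four compounds now lie within the scatter, with none going against this, so neither the pyridinyl groups nor the phenyl groups separate from each other on this read-out, and the place tolerates chloro-, fluoro- and methyl-bearing aromatic rings alike as far as these compounds go. The data shown offer no measurement that could account for this flat result.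

From the compounds shown here alone, what stays open is whether a group of another kind on this nitrogen, such as a piperidine ring, a carboxylic acid or a butyl chain, would give a step beyond the scatter. All four compounds also share one core, so whether the same flat picture holds on a different core remains untold.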